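The compounds below may be only part of what the source reports. "The series", "measured", "known", "first", "only" and "open" are said of these compounds alone.

In an in vitro ADME assay on microsomes from liver (Mus musculus) for pharmacokinetics, read by LC-MS, with a stated time of 10 min, tested at 1 uM (a higher number here means faster removal of the compound, a lower number slower removal), three compounds built on a shared core have been measured. Compound 1 `Cc1ccc(NC(=O)[C@H]2CN(C)C[C@@H]2c2ccc(/C=C/C(=O)Nc3ccccc3N)cc2)cc1` gives 62 mL/min/kg, compound 2 `CC(C)c1ccc(NC(=O)[C@H]2CN(C)C[C@@H]2c2ccc(/C=C/C(=O)Nc3ccccc3N)cc2)cc1` gives 54 mL/min/kg, and compound 3 `CN1C[C@H](C(=O)Nc2ccc(Br)cc2)[C@@H](c2ccc(/C=C/C(=O)Nc3ccccc3N)cc2)C1` gives 16 mL/min/kg, the lowest of the three numbers. Compound 4 `CN1C[C@H](C(=O)Nc2cccc(Cl)c2)[C@@H](c2ccc(/C=C/C(=O)Nc3ccccc3N)cc2)C1` departs from compound 3 on the amide-type nitrogen, where 3-chlorophenyl stands in place of 4-bromophenyl: 3-chlorophenyl in place of 4-bromophenyl on an amide-type nitrogen. Going by the values given here, no measured compound carries 3-chlorophenyl, so the evidence is indirect. Three measured steps exchange a group on an aromatic carbon. The step of a 1.1-fold lower number from compound 1 to compound 2 (0.06 log units; within the scatter) stays within the scatter, while a 3.9-fold lower number from compound 1 to compound 3 (0.59 log units; beyond the scatter) and a 3.4-fold lower number from compound 2 to compound 3 (0.53 log units; beyond the scatter) are modest and go beyond it. Both larger steps introduce the bromo group, which leaves in compound 4. The data do not show whether a chloro group would behave like the bromo group, so a modest rise is expected, no larger than those two steps. The estimated change is a 1.9-fold higher number from compound 3 to compound 4 (0.27 log units; within the scatter). Compound 4 is estimated at 30 mL/min/kg, with an expected range from 14 mL/min/kg to 60 mL/min/kg.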

Compound 4, clearance: 58 mL/min/kg
Compound 4: the middle estimate sits 1.9-fold (0.29 log units) below what was measured, and the stated range covers the measured number.
By their numbers in this assay, from the lowest: compound 3; then compounds 2, 4 and 1 (each within the scatter of the next).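

In this assay, the exchange of 4-bromophenyl for 3-chlorophenyl on the amide-type nitrogen gives a 3.6-fold higher number from compound 3 to compound 4 (0.56 log units; beyond the scatter), so the low number of compound 3 does not extend to every halogen-bearing phenyl group at this position. The other two steps, a 1.1-fold higher number from compound 2 to compound 4 (0.03 log units; within the scatter) and a 1.1-fold lower number from compound 1 to compound 4 (0.03 log units; within the scatter), both lie within the scatter, which leaves compound 3 alone at the low end of the four and places the chloro compound with the two alkyl-bearing compounds. Nothing available explains why these two halogen-bearing groups differ.

Because the halogen and its ring position change together in this step, the compounds shown cannot separate the two, as neither 4-chlorophenyl nor 3-bromophenyl is among them. Also open, as far as these compounds go, is how a phenyl ring bearing a methoxy group or a carboxylic acid would behave here.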